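The source may report more compounds than this note shows. Statements on the series, on what has been measured and on what is new or still open speak of the compounds shown alone.

Compound 3 `Cc1cccc(Oc2ccc(C(=O)N3CCOC3=O)cc2)c1` gives 5210 nM in an assay on HEK293 cells for inhibition of N-acylethanolamine-hydrolyzing acid amidase (Rattus norvegicus), read by LC-MS, with a stated time of 30 min (a lower number here means a stronger inhibitor, a higher number a weaker inhibitor), the highest of the two numbers measured here. Compound 2 `Cc1ccc(CCCCCC(=O)N2CCOC2=O)cc1` gives 440 nM in this assay, a lower number than compound 3, and the gap between them lies beyond the scatter. Compound 1 `O=C(O)c1ccc(CCCCCC(=O)N2CCOC2=O)cc1` reaches only the limit of this assay, > 20000 nM, so its true number is not known, and this is the case described by the limit of > 20000 nM in this assay, at which 1 of the 3 values shown sits.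

Among the measured compounds shown here, the one measured step, an at least 45-fold lower number from compound 1 to compound 2 (1.65 log units; beyond the scatter), is large: removing a carboxy group and putting a methyl in its place lowered the number strongly, and the true size is at least what is stated. Compound 4 `O=C1OCCN1C(=O)c1ccc(OC2CCC(O)CC2)cc1` differs from compound 3 by 4-hydroxycyclohexyl in place of 3-methylphenyl on an oxygen on an aromatic ring. This change brings in a hydroxyl and takes away an aromatic ring, the opposite direction to the step from compound 1 to compound 2, though the groups differ, so a weakening of moderate size is expected. The estimate for compound 4 is 12000 nM, within 3500 nM to 40000 nM, an expected step of a 2.3-fold higher number from compound 3 to compound 4 (0.36 log units; beyond the scatter).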

Compound 4, half-maximal inhibitory concentration: 210 nM
Beside the measured number, compound 4's estimate is 57-fold (1.76 log units) above it, outside the stated range (below it).
By their numbers in this assay, from the lowest: compound 4; then compound 2; then compound 3. At a limit, above all of these: compound 1.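

In this assay, the swap of 3-methylphenyl for 4-hydroxycyclohexyl on an oxygen on an aromatic ring gives a 25-fold lower number from compound 3 to compound 4 (1.39 log units; beyond the scatter), so this place accepts a non-aromatic ring that carries a hydroxyl, and the number falls rather than rises. The two groups have the same count of heavy atoms, so the step comes with a change of ring type and the arrival of a hydrogen-bond donor and acceptor, not with a change in the count of heavy atoms. Nothing measured in the compounds shown accounts for the size of this step.

The compounds shown leave open whether the hydroxyl or the loss of the aromatic ring carries the step. A plain cyclohexyl group or a hydroxyphenyl group on the same oxygen would separate the two, and an amine in place of the hydroxyl would test whether the hydroxyl itself is needed.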